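Purine analogs tested for inhibition in a cell assay

The compounds below may be only part of what the source reports. "The series", "measured", "known", "first", "only" and "open" are said of these compounds alone.

Measured compounds:
compound 1, `CC(=O)OC(C)n1cnc2c(Cl)nc(I)nc21`: 6310 nM
compound 2, `CC(O)n1cnc2c(N)nc(I)nc21`: > 500000 nM
compound 3, `CC(=O)OC(C)n1cnc2c(Cl)nc(F)nc21`: 10000 nM

The three compounds share one fused core and were tested in a functional assay on HEp-2 cells (Homo sapiens) for inhibition; a higher number here means a weaker inhibitor, a lower number a stronger inhibitor. Among the two numbers, compound 3 gives the highest one, and its nearest neighbour is compound 1, a step of a 1.6-fold higher number from compound 1 to compound 3 (0.20 log units; within the scatter), which replaces iodo with fluoro on an aromatic carbon. For compound 2 the result is only a limit of the assay, (the limit of > 500000 nM in this assay, at which 1 of the 3 values shown sits), not a number.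

Compound 4, `CC(=O)OC(C)n1cnc2c(S)nc(F)nc21`, has not been measured. It differs from compound 3 in one place: sulfanyl in place of chloro on an aromatic carbon. Within the data shown here, no measured step touches that position of the core, so the only measured step, the one from compound 1 to compound 3, concerns a different position and lies within the scatter. There is therefore no direct guide for the chloro-to-sulfanyl change, and no property of the sulfanyl group can be inferred from what was measured.

With nothing pointing either way, a modest step of a 1.5-fold higher number from compound 3 to compound 4 (0.18 log units; within the scatter) toward a higher number is expected for compound 4, with wide uncertainty. The estimate for compound 4 in this assay is 15000 nM, expected to fall between 4000 nM and 60000 nM.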

Compound 4, half-maximal inhibitory concentration: 200000 nM
The estimate for compound 4 lay 13-fold (1.12 log units) below the measured number, outside the stated range (above it).
By their numbers in this assay, from the lowest: compounds 1 and 3 (each within the scatter of the next); then compound 4. At a limit, above all of these: compound 2.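

In this assay, among these compounds, this aromatic carbon next to the ring nitrogen proves sensitive to what it carries: a 20-fold higher number from compound 3 to compound 4 (1.30 log units; beyond the scatter) marks a large loss of inhibition, whereas the one earlier measured step, a 1.6-fold higher number from compound 1 to compound 3 (0.20 log units; within the scatter), changed the fluoro position and stayed within the scatter. Swapping one heavy atom for another is therefore enough to make compound 4 a clearly weaker inhibitor than compound 3, even though the rest of the molecule stays the same. The change also brings in a hydrogen-bond donor and acceptor that chloro lacks, but no measurement shown separates these features or gives a cause for the step.

As far as these compounds go, it remains open whether other groups at this carbon, such as bromo, methoxy or methylsulfanyl, would stay close to chloro or fall as far as sulfanyl. From the compounds shown here alone, it is also open whether the same chloro-to-sulfanyl change would have a similar size with the iodo group of compound 1 in place of fluoro.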